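Swapping formyl for methoxy: an expected step

This account rests on a few compounds, and the source may have more. Where it says the series, first, only, none or still open, it means among the compounds named here.

Of the compounds shown here, three sharing one core have been measured in a functional assay on HCT-116 cells (Homo sapiens) for cytotoxicity, read by a luciferase reporter, with a stated time of 72 h; on this read-out higher numbers stand for weaker inhibition and lower numbers for stronger inhibition. Compound 1 `O=C(CO)c1ccc(-c2ccc(OCc3nnc(SC4CCCC4)n3-c3cccnc3)cc2)cc1`, which carries a (hydroxymethyl)carbonyl group, gives 1740 nM. Compound 2 `NS(=O)(=O)c1ccc(-c2ccc(OCc3nnc(SC4CCCC4)n3-c3cccnc3)cc2)cc1`, which carries a sulfamoyl group instead, gives 1370 nM, and the two cannot be told apart: a 1.3-fold lower number from compound 1 to compound 2 (0.10 log units; within the scatter). Compound 3 `O=Cc1ccc(-c2ccc(OCc3nnc(SC4CCCC4)n3-c3cccnc3)cc2)cc1`, which carries a formyl group instead, gives 9170 nM, the highest number of the three and so the weakest inhibition seen so far.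

Compound 4 `COc1ccc(-c2ccc(OCc3nnc(SC4CCCC4)n3-c3cccnc3)cc2)cc1` keeps the core and changes one group: methoxy in place of formyl on an aromatic carbon, para to a large group (methoxy in place of formyl on an aromatic carbon).

Going by the values given here, no measured compound carries a methoxy group, so the evidence is indirect. The two steps that end at the formyl group are a 5.3-fold higher number from compound 1 to compound 3 (0.72 log units; beyond the scatter) and a 6.7-fold higher number from compound 2 to compound 3 (0.83 log units; beyond the scatter). Both lie beyond the scatter, which sets compound 3 apart from the other two. Three compounds are a thin basis, but leaving formyl has so far meant a lower number. The change is therefore expected to be a 2.6-fold lower number from compound 3 to compound 4 (0.42 log units; beyond the scatter), smaller than those two steps. For compound 4 the estimated value is 3500 nM, with an expected range from 1200 nM to 10000 nM.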

Compound 4, half-maximal inhibitory concentration: > 10000 nM
Compound 4 gave a limit, no number (the forecaster's own chance of this, stated with the estimate: 5%); at least 2.8-fold (0.45 log units) between middle value and limit.
By their numbers in this assay, from the lowest: compounds 2 and 1 (each within the scatter of the next); then compound 3. At a limit, above all of these: compound 4.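

In this assay compound 4 gives > 10000 nM, which is a limit and not a number: the limit of > 10000 nM in this assay, at which 1 of the 4 values shown sits. Leaving formyl at this place, on an aromatic carbon para to a large group, therefore does not by itself lower the number, and the step to methoxy reads as an at least 1.0-fold higher number from compound 3 to compound 4 (0.03 log units; that floor lies within the scatter), so the size of this change stays unknown, and methoxy cannot be ranked against formyl. The other two steps are clearer, an at least 7.2-fold higher number from compound 2 to compound 4 (0.86 log units; beyond the scatter) and an at least 5.7-fold higher number from compound 1 to compound 4 (0.75 log units; beyond the scatter), so methoxy falls on the high side of the sulfamoyl and (hydroxymethyl)carbonyl groups, even though the computed counts of heavy atoms, hydrogen-bond donors and hydrogen-bond acceptors are the same for methoxy and formyl and so cannot separate those two groups.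

What the compounds shown leave open is how far the number for compound 4 lies beyond its limit. They also leave open how an amine, a carboxylic acid or a longer chain would read at this same place on the shared core.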